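Shifting the Amide Arm from Compound 2 to Compound 4

This account rests on a few compounds, and the source may have more. Where it says the series, first, only, none or still open, it means among the compounds named here.

Compound 1 `C=CC(=O)Nc1ccc(Cn2nc(-c3ccc(Oc4ccccc4)cc3)cc2C(=O)O)cc1` — in a functional assay on Maver1 cells (Homo sapiens) for inhibition, read by luminescence and CellTiter-Glo, with a stated time of 72 h (a lower number here means a stronger inhibitor, a higher number a weaker inhibitor), compound 1 gives > 60000 nM, which is a limit of the assay rather than a number.
Compound 2 `C=CC(=O)Nc1ccc(Cn2nc(-c3ccc(Oc4ccccc4)cc3)cc2C(=O)OCC)cc1` — in this assay compound 2 gives 13300 nM.
Compound 3 `C=CC(=O)N1CCCC(n2nc(-c3ccc(Oc4ccccc4)cc3)cc2C(=O)O)C1` — in this assay compound 3 gives > 60000 nM, again a limit of the assay.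

Compound 2 is therefore the only one of the three with an actual number; the other two sit at the limit of > 60000 nM in this assay, at which 2 of the 3 values shown sit. For the measured compounds named here, the single measured step is an at least 4.5-fold lower number from compound 1 to compound 2 (0.65 log units; beyond the scatter), which concerns ethyl in place of hydrogen on the oxygen side of the molecule and says nothing about the amide arm.

Compound 4 `C/C=C/C(=O)Nc1cccc(Cn2nc(-c3ccc(Oc4ccccc4)cc3)cc2C(=O)OCC)c1` keeps the ethyl ester of compound 2 and changes the other end: 3-(((prop-1-en-1-yl)carbonyl)amino)phenyl in place of 4-((vinylcarbonyl)amino)phenyl on a saturated chain carbon bound to an aromatic nitrogen. Going by the values given here, no measured step bears on this change, so no direction is supported by the data. Among the compounds with values here, the expectation is therefore anchored on compound 2, because compound 2 gives 13300 nM as the only number available. Compound 4 is estimated at 25000 nM, with a range from 8000 nM to 60000 nM. That estimate means a step of a 1.9-fold higher number from compound 2 to compound 4 (0.27 log units; within the scatter), expected to lie near the scatter, with a real chance that only a limit is reported.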

Compound 4, half-maximal inhibitory concentration: 14200 nM
Compound 4: middle estimate off by 1.8-fold (0.25 log units), on the high side; low and high end bracket the measured number.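

Putting 3-(((prop-1-en-1-yl)carbonyl)amino)phenyl in place of 4-((vinylcarbonyl)amino)phenyl on a saturated chain carbon bound to an aromatic nitrogen gives a 1.1-fold higher number from compound 2 to compound 4 (0.03 log units; within the scatter), so the two compounds cannot be told apart in this assay. The earlier step concerned only the ester end, and this is the first reading at the amide arm, where this change can be made with the ethyl ester kept and no loss shown. The step joins two edits, vinyl to prop-1-en-1-yl and 4- to 3- on the phenyl, and nothing measured here offers a reason for the result.

From the compounds shown here alone, what each edit does alone remains open, as they could offset each other. Also open, going by these compounds, is how the amide arm of compound 4 would fare with a longer chain in place of the ethyl on the ester.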